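A few compounds are considered here, and "the series" means these few. Any claim that something is new, unique, unknown or untested is made for them only; others in the source may bear on it.

Of the compounds shown here, three sharing one core have been measured in an assay on isolated protein for inhibition of Calpain-1 catalytic subunit (Sus scrofa), read by FRET; a higher number here means a weaker inhibitor, a lower number a stronger inhibitor. Compound 1 `O=C(O)/C(S)=C/c1ccc(Cl)cc1` gives 2600 nM. Compound 2 `O=C(O)/C(S)=C/c1ccc(F)cc1` gives 6900 nM. Compound 3 `O=C(O)/C(S)=C/c1ccccc1Cl` gives 11900 nM, the highest of the three numbers, though its gap to compound 2 lies within the scatter and only its gap to compound 1 lies beyond it. Going by the values given here, the one single-point step recorded among them is a 2.7-fold higher number from compound 1 to compound 2 (0.42 log units; beyond the scatter).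

Compound 4 `O=C(O)/C(S)=C/c1ccccc1I` differs from compound 3 by iodo in place of chloro on an aromatic carbon. Among the compounds with values here, no measured step changes the halogen at this place on the ring; the single recorded step concerns a halogen swap at a different carbon, where fluoro in place of chloro moved the number to the weaker side, whereas here iodo replaces chloro. An improvement no greater than modest is therefore expected, and possibly none beyond the scatter. Compound 4 is estimated at 8000 nM, in a range from 3500 nM to 20000 nM. That estimate means an expected step of a 1.5-fold lower number from compound 3 to compound 4 (0.17 log units; within the scatter).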

Compound 4, half-maximal inhibitory concentration: 29600 nM
Compound 4: middle estimate off by 3.7-fold (0.57 log units), on the low side, and the stated range ends below it.
By their numbers in this assay, from the lowest: compound 1; then compounds 2 and 3 (each within the scatter of the next); then compound 4.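

In this assay, going by these compounds alone, iodo in place of chloro on the aromatic carbon ortho to a group of 6 heavy atoms gives a 2.5-fold higher number from compound 3 to compound 4 (0.40 log units; beyond the scatter), which shows that the read-out at this place depends on which halogen it carries, something no earlier step could show. Alongside a 2.7-fold higher number from compound 1 to compound 2 (0.42 log units; beyond the scatter), there are now two steps away from chloro that both end on the weaker side, though they involve different halogens at different carbons and so form no single series. Nothing available explains why iodo is weaker than chloro here.

Going by these compounds, it remains open what bromo, a methyl group or a methoxy group would do at this carbon, and whether iodo would also weaken the compound at the carbon bearing chloro in compound 1. On these data alone, how far the reading depends on the carboxylic acid or the thiol of the shared core also remains open.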